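Amide side-chain amine swap in a diaryl-ethene series

The source may report more compounds than this note shows. Statements on the series, on what has been measured and on what is new or still open speak of the compounds shown alone.

Measured compounds:
compound 1 `C=C(c1ccc(OC)cc1NC(=O)CNCC)c1ccc(OC)c2c1C=CC(C)(C)O2`: 2010 nM
compound 2 `C=C(c1cc(OC)c(OC)c(OC)c1)c1ccc(OC)cc1NC(=O)CNCC`: 450 nM
compound 3 `C=C(c1ccc(OC)cc1NC(=O)CN(C)C)c1ccc(OC)c2c1C=CC(C)(C)O2`: 670 nM

In a functional assay on A2780 cells (Homo sapiens) for antiproliferative activity, read by MTT assay, with a stated time of 48 h (a lower number here means a stronger inhibitor, a higher number a weaker inhibitor), compound 1 gives 2010 nM, while compound 3 gives 670 nM. The change between them is dimethylamino in place of ethylamino on a saturated chain carbon bound to a carbonyl carbon, and the step is a 3.0-fold lower number from compound 1 to compound 3 (0.48 log units; beyond the scatter). Compound 2 carries a different core; the difference between the two cores is not broken down here. Compound 4 `C=C(c1cc(OC)c(OC)c(OC)c1)c1ccc(OC)cc1NC(=O)CN(C)C` is not yet measured and differs from compound 2 by dimethylamino in place of ethylamino on a saturated chain carbon bound to a carbonyl carbon, the same change seen from compound 1 to compound 3. A similar step is expected, damped somewhat since the core differs: a 2.3-fold lower number from compound 2 to compound 4 (0.35 log units; beyond the scatter) is the estimate, resting on the step from compound 1 to compound 3 a 3.0-fold lower number from compound 1 to compound 3 (0.48 log units; beyond the scatter). Compound 4 is therefore expected to give about 200 nM, likely between 100 nM and 450 nM in this assay.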

Compound 4, half-maximal inhibitory concentration: 240 nM
Estimate against measurement, compound 4: 1.2-fold (0.08 log units) below; the measured number falls inside the stated range.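

In this assay, dimethylamino in place of ethylamino on a saturated chain carbon bound to a carbonyl carbon gives a 1.9-fold lower number from compound 2 to compound 4 (0.27 log units; within the scatter), so on the core of compound 2 the change alone cannot be told apart from the scatter. Set beside the step on the core of compound 1, the two steps do not differ: the same change on two cores in this assay, a 3.0-fold lower number (0.48 log units; beyond the scatter) from compound 1 to compound 3 and a 1.9-fold lower number (0.27 log units; within the scatter) from compound 2 to compound 4, 1.6-fold (0.20 log units) apart, within the scatter of two such steps. This fits a change that carries over between these two cores, but it rests on one pair per core and does not show that the change carries to any other core.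

The compounds shown leave open how diethylamino, pyrrolidine or morpholine would behave in the same place. On these data alone, an unsubstituted amine there also remains open.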